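Aryl hydrazone acids: a third step without a readable number

This account rests on a few compounds, and the source may have more. Where it says the series, first, only, none or still open, it means among the compounds named here.

Compound 1, `CC1CC/C(=N\Nc2ccccc2)c2nccc(=O)n21`: > 100 umol/kg
Compound 2, `CC1CC/C(=N\Nc2ccc(F)cc2)c2ncc(C(=O)O)c(=O)n21`: > 1000 umol/kg
Compound 3, `CC1CC/C(=N\Nc2cccc(Br)c2)c2ncc(C(=O)O)c(=O)n21`: > 320 umol/kg

Every value measured in a functional assay on the whole organism for inhibition, with Rattus norvegicus as the target (a higher number here means that more compound is needed for the effect, a lower number that less compound is needed), is a limit of the assay, not a number. Compound 1 stops at > 100 umol/kg. Compound 2 stops at > 1000 umol/kg. Compound 3 stops at > 320 umol/kg, and this limit is where it stands, with the two other values also being limits (the limit of > 100 umol/kg in this assay, at which 1 of the 3 values shown sits, (the limit of > 1000 umol/kg in this assay, at which 1 of the 3 values shown sits), (the limit of > 320 umol/kg in this assay, at which 1 of the 3 values shown sits)). For the measured compounds named here, the only measured step, a step that the two limits leave unreadable from compound 2 to compound 3, has no readable size. Compound 4, `COc1ccccc1N/N=C1\CCC(C)n2c1ncc(C(=O)O)c2=O`, differs from compound 3 by 2-methoxyphenyl in place of 3-bromophenyl on an amine nitrogen. Going by the values given here, no measured step bears on this change, so no direction beyond the scatter can be expected. Compound 4 is estimated at 500 umol/kg, between 100 umol/kg and 3000 umol/kg, most likely again only as a limit. The expected step is a step that the limit leaves unreadable from compound 3 to compound 4.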

Compound 4, dose for 50% inhibition: > 1000 umol/kg
Compound 4 gave a limit, no number; the forecaster's own chance of this, stated with the estimate: 80%; middle value at least 2.0-fold (0.30 log units) from the limit.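

Compound 4 gives only a limit in this assay, as do compound 2 and compound 3, so the steps to compound 4 from compound 2 and compound 3 cannot be read. Going by these compounds, whether changing the aromatic group on the amine nitrogen alters the dose needed remains open.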